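This account rests on a few compounds, and the source may have more. Where it says the series, first, only, none or still open, it means among the compounds named here.

Of the compounds shown here, two that share one core have so far been measured in a functional assay on HL-60 cells (Homo sapiens) for cytotoxicity, read by WST assay, with a stated time of 48 h; a higher number here means that more compound is needed for the effect, a lower number that less compound is needed. Compound 1 (`CCCCOc1ccc(C[C@H]2C(=O)OC[C@@H]2Cc2ccccc2)cc1`) gives 23000 nM in this test, and compound 2 (`CCCCOc1cc(C[C@H]2C(=O)OC[C@@H]2Cc2ccccc2)ccc1O`) gives 35000 nM in the same test. Compound 2 therefore stands within the scatter of compound 1, and the two values cannot be told apart.

Compound 3 (`CCCCOc1ccc(C[C@H]2C(=O)OC[C@@H]2Cc2ccccc2)cc1OCCCC`) has yet to be measured in this assay and departs from compound 2 in one place. The change is butyl in place of hydrogen on an oxygen on an aromatic ring and reads as hydroxy to butoxy, with butyl in place of hydrogen on an oxygen on an aromatic ring.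

Within the data shown here, no measured pair shows the size of such a change directly. Among the measured compounds shown here, the only guide is the pair of values already in hand, where compound 1, which carries no hydroxy, gives 23000 nM and compound 2, which does carry one, gives 35000 nM within the scatter of it. No step beyond the scatter is therefore expected, and the estimated step is a 1.6-fold lower number from compound 2 to compound 3 (0.20 log units; within the scatter) in size. For compound 3 the expected value is 22000 nM with an estimated range from 9000 nM to 50000 nM.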

Compound 3, half-maximal effective concentration: > 100000 nM
Compound 3: no number, only a limit (the forecaster's own chance of this, stated with the estimate: 15%); middle value at least 4.5-fold (0.65 log units) away from the limit.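

In this assay compound 3 gives no number, only a limit: the limit of > 100000 nM in this assay, at which 1 of the 3 values shown sits.

Even so, this is the first change at this place that can be read as a real step: butyl in place of hydrogen on an oxygen on an aromatic ring gives an at least 2.8-fold higher number from compound 2 to compound 3 (0.45 log units; beyond the scatter), whereas the two earlier compounds stood within the scatter of each other and showed no step at all. Butoxy in place of hydrogen on an aromatic carbon points the same way, with an at least 4.3-fold higher number from compound 1 to compound 3 (0.63 log units; beyond the scatter), so at this place a hydroxy leaves the number within the scatter of the compound without it, while a butoxy moves it beyond the scatter, and both steps are only floors whose full size stays unknown.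

The compounds shown leave open whether a methyl on this oxygen would already give such a step or whether it takes a chain as long as butyl. They also leave open whether an amine or a carboxylic acid at the end of that chain would bring the number back within reach of the assay.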